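Working notes on compound 3 and compound 4

The compounds below may be only part of what the source reports. "The series", "measured", "known", "first", "only" and "open" are said of these compounds alone.

Three compounds have numbers in an assay on isolated protein for inhibition of Flap endonuclease 1 (Homo sapiens); a lower number here means a stronger inhibitor, a higher number a weaker inhibitor. Compound 1 `CC(=O)Nc1cccc2c(=O)n(O)c(=O)[nH]c12` gives 38 nM. Compound 2 `CC(=O)Nc1ccc2c(=O)n(O)c(=O)[nH]c2c1` gives 2100 nM. Compound 3 `CNC(=O)c1nc(-c2cccs2)[nH]c(=O)c1O` gives 12000 nM, the highest of the three numbers; compound 2 has the nearest number and compound 1 the furthest, and both gaps lie beyond the scatter. No two of these compounds differ in one place only, so no single step is on record, and compound 3 stands apart from compound 1 and compound 2 both in build and on the numbers.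

Compound 4 `CCC(C)NC(=O)c1nc(-c2cccs2)[nH]c(=O)c1O` has not been measured. It differs from compound 3 in one place: sec-butyl in place of methyl on an amide-type nitrogen. For the measured compounds named here, nothing among the measured compounds shows what a change of this kind does in this assay, so no step of this type is known. The expectation is a small step in either direction, or none beyond the scatter. For compound 4 the expected value in this assay is 8000 nM, estimated to fall between 2500 nM and 25000 nM. The step this estimate means is expected to be a 1.5-fold lower number from compound 3 to compound 4 (0.18 log units; within the scatter).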

Compound 4, half-maximal inhibitory concentration in the Flap endonuclease 1 assay: 1300 nM
Compound 4: middle estimate off by 6.2-fold (0.79 log units), on the high side; the whole stated range lies above it.
By their numbers in the Flap endonuclease 1 assay, from the lowest: compound 1; then compounds 4 and 2 (each within the scatter of the next); then compound 3.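

For the compounds shown here, the amide-type nitrogen is a position that responds in the Flap endonuclease 1 assay: sec-butyl in place of methyl gives a 9.2-fold lower number from compound 3 to compound 4 (0.97 log units; beyond the scatter), the first single change on record. The position therefore accepts a group larger than methyl, and in this pair the number falls with that change. In a physicochemical assay for permeability, using PAMPA (on this read-out lower numbers stand for lower permeability and higher numbers for higher permeability), compound 3 gives 31 nm/s and compound 4 gives 97 nm/s. In the physicochemical assay the same change comes with higher permeability: the measured apparent permeability of compound 3, 31 nm/s, and of compound 4, 97 nm/s, a 3.1-fold higher number (0.50 log units; beyond the scatter)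

This single pair does not separate the effect of chain length from that of branching, and an n-butyl chain or an isopropyl group on the same nitrogen would begin to do so. Also open, on these data alone, is how a cyclopentyl ring or a chain ending in a carboxylic acid or an amine at this position would read in the Flap endonuclease 1 assay and in the physicochemical assay.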